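Dropping the Second Ring Nitrogen: From Compound 2 to Compound 4

This account rests on a few compounds, and the source may have more. Where it says the series, first, only, none or still open, it means among the compounds named here.

Three compounds share one core, an alkoxy-benzamide linked through a methylene to a cyclohexane that carries a basic ring. In an assay on HEK293 cells for inhibition of potassium/sodium hyperpolarization-activated cyclic nucleotide-gated channel 1 (Homo sapiens), with a stated time of 30 min (on this read-out lower numbers stand for stronger inhibition and higher numbers for weaker inhibition), compound 2 `CCOc1ccccc1C(=O)NCC1(N2CCN(CC)CC2)CCCCC1` gives 31.6 nM, the lowest of the three numbers. Compound 3 `CCOc1ccccc1C(=O)NCC1(N2CCN(C3CCC3)CC2)CCCCC1` gives 79.4 nM in this assay, and compound 1 `CC(C)Oc1ccccc1C(=O)NCC1(N2CCN(C(C)C)CC2)CCCCC1` gives 251 nM. Among the measured compounds shown here, the one single-point step known is a 2.5-fold higher number from compound 2 to compound 3 (0.40 log units; beyond the scatter), a modest loss when the ethyl on the ring nitrogen grows to a cyclobutyl.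

Compound 4 `CCOc1ccccc1C(=O)NCC1(N2CCCCC2)CCCCC1` goes further: piperidin-1-yl in place of 4-ethylpiperazin-1-yl on a saturated ring carbon. For the measured compounds named here, no measured pair removes this nitrogen and its substituent outright, so the step of a 2.5-fold higher number from compound 2 to compound 3 (0.40 log units; beyond the scatter) is the only guide, and it shows that what sits on that nitrogen already shifts the number beyond the scatter. Taking the nitrogen away entirely is therefore expected to cost more than that step did, giving an estimated 5.1-fold higher number from compound 2 to compound 4 (0.70 log units; beyond the scatter). Compound 4 is estimated at 160 nM, with a likely range from 40 nM to 630 nM in this assay.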

Compound 4, half-maximal inhibitory concentration: 15800 nM
For compound 4 the middle estimate is 99-fold (1.99 log units) below the measured one; the measured number lies above the stated range.
By their numbers in this assay, from the lowest: compound 2; then compound 3; then compound 1; then compound 4.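

In this assay, among the compounds shown here, the earlier compounds only varied what sits on the ring nitrogen, and that gave a 2.5-fold higher number from compound 2 to compound 3 (0.40 log units; beyond the scatter) as a modest step. Replacing the whole 4-ethylpiperazin-1-yl with piperidin-1-yl gives a 500-fold higher number from compound 2 to compound 4 (2.70 log units; beyond the scatter) as a large step, so this position tolerates a change of substituent on that nitrogen far better than the loss of the nitrogen and its ethyl together. No measurement at hand explains why this step is so large.

The change removes a ring nitrogen and an ethyl at once, so the compounds shown cannot say which loss matters more. A 4-ethylpiperidin-1-yl, which keeps the ethyl, or a plain piperazin-1-yl, which keeps the nitrogen, would separate the two, and a morpholin-4-yl would show the effect of a ring oxygen there.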